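Hydrogen in place of methyl: compound 3 to compound 4

A few compounds are considered here, and "the series" means these few. Any claim that something is new, unique, unknown or untested is made for them only; others in the source may bear on it.

In a functional assay on T47D cells (Homo sapiens) for inhibition, read by CCK-8 assay, with a stated time of 72 h, tested at 10 uM (a lower number here means less inhibition of growth, a higher number more inhibition of growth at the concentration tested), compound 1 `CN(C)C(=O)c1cc2cnc(Nc3ccc(NC(=O)C4(C(=O)Nc5ccc(F)cc5)CC4)cc3)nc2n1C1CCCC1` gives 105% and compound 2 `CN(C)C(=O)c1cc2cnc(Nc3ccc(NC(=O)C4(C(=O)Nc5ccc(Cl)cc5)CC4)cc3)nc2n1C1CCCC1` gives 95% while compound 3 `Cc1ccc(NC(=O)C2(C(=O)Nc3ccc(Nc4ncc5cc(C(=O)N(C)C)n(C6CCCC6)c5n4)cc3)CC2)cc1` gives 99.6% in the same read-out. On these numbers compound 3 lies within the scatter of compound 1 and compound 2 alike.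

Compound 4 `CN(C)C(=O)c1cc2cnc(Nc3ccc(NC(=O)C4(C(=O)Nc5ccccc5)CC4)cc3)nc2n1C1CCCC1` is the next case. The change hydrogen in place of methyl on an aromatic carbon puts hydrogen in place of methyl on an aromatic carbon, para to a large group. For the measured compounds named here, no measured compound carries hydrogen there, so the series holds no direct precedent. The nearest evidence is the exchange of one substituent for another at that place: a number 10 percentage points lower from compound 1 to compound 2 (within the scatter) and a number 5.4 percentage points lower from compound 1 to compound 3 (within the scatter) and a number 4.6 percentage points higher from compound 2 to compound 3 (within the scatter) are the three steps, and all stay within the scatter.

On that basis no step beyond the scatter is expected, and the estimated change is a number 1.6 percentage points lower from compound 3 to compound 4 (within the scatter) in this read-out. Compound 4 is estimated at 98% with an expected range of 85% to 108% as the working figure.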

Compound 4, percent growth inhibition at one concentration: 93.9%
Compound 4: middle estimate off by 4.1 percentage points, on the high side, within the range that was stated.
By their numbers in this assay, from the lowest: compounds 4, 2, 3 and 1 (each within the scatter of the next, the first and the last beyond it).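

In this assay, hydrogen on this aromatic carbon, para to a large group, gives a number 5.7 percentage points lower from compound 3 to compound 4 (within the scatter) and a number 1.1 percentage points lower from compound 2 to compound 4 (within the scatter), so neither methyl nor chloro separates from hydrogen at this place. Fluoro alone does, with a number 11.1 percentage points lower from compound 1 to compound 4 (beyond the scatter), the first step in the series beyond the scatter; it is a modest step, and this one pair is the only sign that the position is not flat. Nothing available bears on why compound 1 and compound 4 stand apart.

The compounds shown leave open whether an amine, a carboxylic acid or a methoxy group at this place would move the reading any further than these small substituents do. Also open, on these data alone, is whether the gap between compound 1 and compound 4 would hold at other concentrations, since a single concentration gives no dose response.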